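Aryl swap on the anilino nitrogen of a urea core

The source may report more compounds than this note shows. Statements on the series, on what has been measured and on what is new or still open speak of the compounds shown alone.

Measured compounds in a functional assay on NCI-H520 cells (Homo sapiens) for inhibition, read by MTT assay, with a stated time of 48 h, tested at 10 uM; a lower number here means less inhibition, a higher number more inhibition at the concentration tested (going by the name of the read-out):
compound 1 `COc1cc(Br)ccc1Nc1cc(NC(=O)Nc2c(Cl)cccc2Cl)ncn1`: 29.1%
compound 2 `COc1ccc(C(F)(F)F)cc1Nc1cc(NC(=O)Nc2c(Cl)cccc2Cl)ncn1`: 33%
compound 3 `COc1cc(NC(=O)Nc2cc(Nc3ccc(Br)cc3OC)ncn2)cc(OC)c1`: 36.1%

Compound 1 gives the lowest of the three numbers in this assay, yet its nearest neighbour is compound 2 and the furthest is compound 3, and both gaps lie within the scatter; the three measured compounds are therefore indistinguishable on this read-out. Within the data shown here, the only step between compounds differing in one place, a number 7 percentage points higher from compound 1 to compound 3 (within the scatter), exchanges the group on the amide-type nitrogen and is within the scatter as well.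

Compound 4 `COc1ccc(Nc2cc(NC(=O)Nc3c(Cl)cccc3Cl)ncn2)cc1C` has not been measured. It differs from compound 1 as follows: 4-methoxy-3-methylphenyl in place of 4-bromo-2-methoxyphenyl on a nitrogen on an aromatic ring. Among the measured compounds shown here, no measured step changes this position alone; compound 2 carries a different group there than compound 1, and its value is within the scatter of compound 1. The data thus give no reason to expect a step beyond the scatter. The author estimates compound 4 at 31%, ranging from 18% to 45% in this assay. This expected step, a number 1.9 percentage points higher from compound 1 to compound 4 (within the scatter), is estimated to stay within the scatter.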

Compound 4, a percentage reported as inhibition, at one concentration (the size of the read-out at that concentration, not a potency): 29.1%
Compound 4: the middle estimate sits 1.9 percentage points above what was measured, within the range that was stated.
By their numbers in this assay, from the lowest: compounds 1, 4, 2 and 3 (each within the scatter of the next).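

The first change measured at this position alone gives, in this assay, no change at the digits printed from compound 1 to compound 4 (within the scatter), so this exchange on a nitrogen on an aromatic ring leaves the two compounds inseparable at the single concentration tested. Among these compounds, the 4-bromo-2-methoxyphenyl group carries the only bromine in compound 1, and the 4-methoxy-3-methylphenyl group of compound 4 has only carbon and oxygen, so in this pair the read-out does not depend on the presence of that bromine, although this percentage is not a measure of potency. Nothing measured here explains why the two groups read alike.

The compounds shown leave open whether this position responds to anything other than a substituted phenyl ring, such as a piperidine or a phenyl ring bearing a carboxylic acid or a longer alkyl chain. They also leave open whether the 4-methoxy-3-methylphenyl group would read the same with the 3,5-dimethoxyphenyl group on the other amide-type nitrogen, since only the 2,6-dichlorophenyl partner appears with it here.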